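Ethyl for methyl on a succinimide-bearing amide chain

The source may report more compounds than this note shows. Statements on the series, on what has been measured and on what is new or still open speak of the compounds shown alone.

Measured compounds:
compound 1, `CC(C(=O)NCc1cccc(F)c1)N1C(=O)CCC1=O`: "not determined" (no result reported)
compound 2, `CCC(C(=O)NCc1ccc(Cl)cc1)N1C(=O)CCC1=O`: 50.8 mg/kg

Compound 1 has the structure `CC(C(=O)NCc1cccc(F)c1)N1C(=O)CCC1=O`. In a functional assay on the whole organism (strain Albino Swiss CD1) with Mus musculus as the target (a lower number here means that less compound is needed, a higher number that more compound is needed for the effect), compound 1 gives "not determined" (no result reported), so compound 1 stands with no single number in this set. Among the measured compounds shown here, compound 2, with the structure `CCC(C(=O)NCc1ccc(Cl)cc1)N1C(=O)CCC1=O`, shares the core but carries a different halogen on the benzyl ring and an ethyl rather than a methyl side chain; in this assay compound 2 gives 50.8 mg/kg, the only number on record here.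

Compound 3 has the structure `CCC(C(=O)NCc1cccc(F)c1)N1C(=O)CCC1=O`. It differs from compound 1 by methyl in place of hydrogen on a saturated chain carbon, two bonds along the chain from an amide-type nitrogen in a ring and a carbonyl carbon. For the measured compounds named here, no step between two measured compounds shows what this change alone does in this assay, so neither its direction nor its size can be read from the data; the change is small enough that no step beyond the usual scatter is assumed. Because compound 2 gives 50.8 mg/kg, compound 3 is expected to land near that figure, at an estimated 55 mg/kg with a range from 25 mg/kg to 130 mg/kg.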

Compound 3, dose for half-maximal effect: 47.4 mg/kg
Compound 3: the middle estimate sits 1.2-fold (0.06 log units) above what was measured, and the stated range covers the measured number.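

With the ethyl side chain the same in both compounds, the aromatic group can now be judged on its own: 3-fluorophenyl in place of 4-chlorophenyl, on a saturated chain carbon bound to an amide-type nitrogen, gives a 1.1-fold lower number from compound 2 to compound 3 (0.03 log units; within the scatter) in this assay for this pair. The halogen and its place on the ring both differ across this step, yet the two compounds cannot be told apart in this read-out, so this particular exchange shows no measurable effect on the dose needed. No supporting data are available to explain this result.

On these data alone, compound 1 has no number, so the step from it to compound 3 cannot be read, and the effect of going from methyl to ethyl on the saturated chain carbon remains unknown. Also open, as far as these compounds go, is how a longer chain such as propyl would fare in place of the ethyl, and whether plain phenyl, carrying no halogen at all, would behave like 3-fluorophenyl and 4-chlorophenyl.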